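The source may report more compounds than this note shows. Statements on the series, on what has been measured and on what is new or still open speak of the compounds shown alone.

Compound 1 `CC(CCNC(=O)c1c(Cl)cncc1Cl)N1CCC(C(Oc2ncccc2Cl)c2ccc(C(F)(F)F)cc2)CC1` – 16700 nM
Compound 2 `CC(CCNC(=O)c1c(Cl)cncc1Cl)N1CCC(C(Oc2ccccc2C#N)c2ccc(C(F)(F)F)cc2)CC1` – 17000 nM

Among the measured compounds shown here, in an ADME assay on PBMC cells (Homo sapiens) for cytotoxicity (a lower number here means that less compound is tolerated, a higher number that more compound is tolerated), compound 2 gives 17000 nM and stands level with compound 1, the only other measured compound, as the two values lie within the scatter of each other. Compound 3 `CC(CCNC(=O)c1c(Cl)cncc1Cl)N1CCC(C(Oc2ccccc2Cl)c2ccc(C(F)(F)F)cc2)CC1` differs from compound 2 by chloro in place of cyano on an aromatic carbon, turning 2-cyanophenyl into 2-chlorophenyl (chloro in place of cyano on an aromatic carbon). For the measured compounds named here, only one measured step bears on this change (a 1.0-fold higher number from compound 1 to compound 2 (0.01 log units; within the scatter)), and it lies within the scatter. In that step 2-cyanophenyl took the place of 3-chloropyridin-2-yl, so cyano and chloro were exchanged along with the ring, with no shift beyond the scatter in this assay as the result. Going by the values given here, no measured step isolates the exact change, so the expectation stays loose. No step beyond the scatter is expected (a 1.1-fold lower number from compound 2 to compound 3 (0.04 log units; within the scatter)). For compound 3 the estimate is 15500 nM (expected range 8500 nM to 27000 nM).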

Compound 3, half-maximal cytotoxic concentration: 4400 nM
For compound 3 the middle estimate is 3.5-fold (0.55 log units) above the measured one, and the stated range ends above it.
By their numbers in this assay, from the lowest: compound 3; then compounds 1 and 2 (each within the scatter of the next).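

On the six-membered aromatic ring of carbon only, the group ortho to a large group clearly counts in this assay: chloro in place of cyano gives a 3.9-fold lower number from compound 2 to compound 3 (0.59 log units; beyond the scatter). The ring itself counts as well, since 2-chlorophenyl in place of 3-chloropyridin-2-yl gives a 3.8-fold lower number from compound 1 to compound 3 (0.58 log units; beyond the scatter), so the earlier level pair, compound 1 and compound 2, differed in both ring and group and did not show that each change can matter on its own. Nothing measured here explains why compound 3 is tolerated less than the other two.

As far as these compounds go, it remains open how fluoro, methyl or methoxy would read in this place on the phenyl ring. Also open, from the compounds shown here alone, is where 3-cyanopyridin-2-yl, which joins the nitrile to the ring of compound 1, would fall.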